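The compounds below may be only part of what the source reports. "The series", "measured", "known", "first", "only" and "open" are said of these compounds alone.

Three members of the series have been run in a functional assay on CHO cells with adenosine receptor A1 (Homo sapiens) as the target, read by cAMP accumulation and immunoassay, with a stated time of 6 min, tested at 0.01 uM; a higher number here means a weaker effect of the compound at the concentration tested, a lower number a stronger effect. Compound 1 `Nc1scc(CN2CCN(c3ccc(F)cc3Cl)CC2)c1C(=O)c1ccc(Cl)cc1` gives 6.1%. Compound 2 `Nc1scc(CN2CCN(c3cccc(F)c3)CC2)c1C(=O)c1cccc(C(F)(F)F)c1` gives -11%. Compound 3 `Nc1scc(CN2CCN(C3CCCCCC3)CC2)c1C(=O)c1ccc(Cl)cc1` gives 2.9%. On these numbers compound 3 stands second highest of three; its nearest neighbour is compound 1, at a distance within the scatter, and its furthest is compound 2, at a distance beyond it.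

The next compound, compound 4 `Nc1scc(CN2CCN(c3cccc(Cl)c3)CC2)c1C(=O)c1ccc(Cl)cc1`, arises from compound 3 by one change: 3-chlorophenyl in place of cycloheptyl on an amine nitrogen in a ring. Going by the values given here, one measured step bears on it directly, the change in the opposite sense on an amine nitrogen in a ring, which gave a number 3.2 percentage points lower from compound 1 to compound 3 (within the scatter). That step did not move the read-out beyond the scatter, so placing an aromatic ring back on that amine nitrogen in a ring is expected to leave the number near where compound 3 sits. Among the compounds with values here, compounds 1 and 2 differ in two places at once, so their values show only that an aryl group there is compatible with either sign of read-out. The step of a number 2.1 percentage points higher from compound 3 to compound 4 (within the scatter) is therefore expected to be small, not beyond the scatter, in either direction. Compound 4 is estimated at 5%, with a range from -7% to 17%.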

Compound 4, a percentage reported as activity, at one concentration (the size of the read-out at that concentration, not a potency): -3.1%
Beside the measured number, compound 4's estimate is 8.1 percentage points above it, within the range that was stated.
By their numbers in this assay, from the lowest: compounds 2, 4, 3 and 1 (each within the scatter of the next, the first and the last beyond it).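

With the rest of the molecule held constant in this assay, 3-chlorophenyl in place of cycloheptyl on the amine nitrogen in a ring gives a number 6 percentage points lower from compound 3 to compound 4 (within the scatter), and 3-chlorophenyl in place of 2-chloro-4-fluorophenyl gives a number 9.2 percentage points lower from compound 1 to compound 4 (within the scatter). Going by these compounds alone, the second of these is the first comparison between two differently substituted phenyl groups at this position, and taken with the earlier cycloheptyl step, it means that none of the three groups can be told apart from the others in this read-out at the concentration tested. No measurement is available that accounts for these small steps.

On these data alone, what remains open is whether a group of a different kind on this nitrogen, such as a chain ending in a primary amine or a carboxylic acid, would move the read-out beyond the scatter. Compound 2, at -11%, differs from each of the other compounds in more than one place, and the compounds shown do not separate any contribution of its trifluoromethyl group from that of its 3-fluorophenyl group.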